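The compounds below may be only part of what the source reports. "The series", "measured", "known", "first", "only" and "open" are said of these compounds alone.

The three measured compounds, all tested in a functional assay on HT-29 cells (Homo sapiens) for cytotoxicity, read by MTT assay, with a stated time of 24 h, tested at 0.64 ug/mL; on this read-out lower numbers stand for a weaker effect and higher numbers for a stronger effect at the one concentration tested:

compound 1 `Cn1c(-c2ccc(NC(=O)CSc3nc4ccccc4s3)cc2)nc(-c2ccccc2)c1-c1ccccc1`: 9.8%
compound 2 `Cn1cnnc1SCC(=O)Nc1ccc(-c2nc(-c3ccccc3)c(-c3ccccc3)n2C)cc1`: 32%
compound 3 `CN(C)/C=C/N1CCN(CC(=O)Nc2ccc(-c3nc(-c4ccccc4)c(-c4ccccc4)n3C)cc2)CC1`: 3.1%

Compound 3 gives the lowest of the three numbers in this assay, but its gap to compound 1 is small: a number 6.7 percentage points lower from compound 1 to compound 3 (within the scatter). Against compound 2 it stands further off, as a number 28.9 percentage points lower from compound 2 to compound 3 (beyond the scatter) shows, and compound 2 in turn sits apart from compound 1, with a number 22.2 percentage points higher from compound 1 to compound 2 (beyond the scatter). All three share a core and an amide link; they differ only in the group carried on the saturated chain carbon bound to the carbonyl carbon.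

Compound 4 `COc1ccc(CN2CCN(CC(=O)Nc3ccc(-c4nc(-c5ccccc5)c(-c5ccccc5)n4C)cc3)CC2)cc1` keeps the piperazine-bearing side chain of compound 3 and changes it at a single point: 4-methoxybenzyl in place of 2-(dimethylamino)ethenyl on an amine nitrogen in a ring. Going by the values given here, no measured step alters this position; the two steps that reach compound 3 each swapped the whole side group, so none of them bears directly on this change. The available steps span a modest range, and the nearest analogue, compound 3, lies at the low end of it. Compound 4 is therefore expected to stay in the weak range, with a number 4.9 percentage points higher from compound 3 to compound 4 (within the scatter) as the estimated step, not beyond the scatter. The estimate for compound 4 in this assay is 8%, within a range from 0% to 28%.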

Compound 4, a percentage reported as activity, at one concentration (the size of the read-out at that concentration, not a potency): 5.2%
Beside the measured number, compound 4's estimate is 2.8 percentage points above it; low and high end bracket the measured number.
By their numbers in this assay, from the lowest: compounds 3, 4 and 1 (each within the scatter of the next); then compound 2.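

Going by these compounds alone, this is the first measured change at the amine nitrogen in the ring: in this assay, 4-methoxybenzyl in place of 2-(dimethylamino)ethenyl gives a number 2.1 percentage points higher from compound 3 to compound 4 (within the scatter). The earlier steps shown here exchanged the whole side group, whereas this one keeps the rest of that side group and shows that going from 5 heavy atoms with no ring to 9 heavy atoms with a six-membered aromatic ring of carbon only, while losing the double bond outside aromatic rings, does not move the number beyond the scatter. Nothing available explains why these two groups read alike at this position.

With only these two groups on that nitrogen, the compounds shown leave open whether a different kind of group there, such as a carboxylic acid on a longer chain or a simple methyl, would separate from them in this assay. They also leave open whether compound 3 and compound 4 would still read alike at another concentration, for the one concentration shown cannot speak to potency.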